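Three Stereoisomers at the Limit, a Fourth Awaited

This account rests on a few compounds, and the source may have more. Where it says the series, first, only, none or still open, it means among the compounds named here.

Compound 2 `O=C(O)[C@@H](CO)NC(=O)[C@H]1C[C@H](O)CN1` stands at the upper edge of what an ADME assay (Mus musculus, strain C57BL/6) for metabolic stability, read by HPLC, with a stated time of 12 h (on this read-out higher numbers stand for a longer-lived compound and lower numbers for a shorter-lived compound), can report: in this assay compound 2 gives > 12 h, which is a limit of the assay and not a number. Compound 1 `O=C(O)[C@H](CO)NC(=O)[C@H]1C[C@H](O)CN1` likewise gives > 12 h in this assay, again a limit. Compound 3 `O=C(O)[C@H](CO)NC(=O)[C@H]1C[C@@H](O)CN1` gives > 12 h in this assay, also a limit. Because all three values sit at the limit of > 12 h in this assay, at which 3 of the 3 values shown sit, none of the steps among them can be read: a step that the two limits leave unreadable from compound 1 to compound 2, a step that the two limits leave unreadable from compound 1 to compound 3 and a step that the two limits leave unreadable from compound 2 to compound 3 have no readable size, even though each pair differs only in configuration as drawn (the fact that compounds 1 and 2 differ only in the configuration as drawn, (the fact that compounds 1 and 3 differ only in the configuration as drawn), (the fact that compounds 2 and 3 differ only in the configuration as drawn)).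

Compound 4 `O=C(O)[C@H](CO)NC(=O)[C@@H]1C[C@H](O)CN1` differs from compound 2 as follows: the two compounds have the same atoms and bonds and differ only in configuration as drawn: 2 of 3 stereo elements differ; a stereocentre at a saturated chain carbon is drawn R in compound 2 and S in compound 4; a stereocentre at a saturated ring carbon is drawn R in compound 2 and S in compound 4. Every measured change of configuration, including the one that alters two of three stereo elements, left the compound at the limit of this assay, so no direction can be taken from the measured steps. The expectation for compound 4 is therefore that it too reaches the limit of this assay. Compound 4 is estimated to give 14 h in this assay, within 8 h to 24 h. The step that the limit leaves unreadable from compound 2 to compound 4 is expected to be none beyond the scatter.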

Compound 4, half-life: 1.22 h
For compound 4 the middle estimate is 11-fold (1.06 log units) above the measured one, outside the stated range (below it).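

At one saturated ring carbon, drawn R in compound 1 and S in compound 4, a change of configuration alone gives an at least 9.8-fold lower number from compound 1 to compound 4 (0.99 log units; beyond the scatter) in this assay, so this read-out does respond to stereochemistry: the fact that compounds 1 and 4 differ only in the configuration as drawn. The two other steps, an at least 9.8-fold lower number from compound 2 to compound 4 (0.99 log units; beyond the scatter) and an at least 9.8-fold lower number from compound 3 to compound 4 (0.99 log units; beyond the scatter), point the same way, and all three sizes are minimum sizes, since compounds 1, 2 and 3 each stand at a limit of the assay and not at a number. Among the four compounds, the three drawn R at this ring carbon all reach the limit while compound 4, the only one drawn S there, does not, and no compound shown goes against this pattern.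

From the compounds shown here alone, the steps among compounds 1, 2 and 3 still cannot be read, and with only compound 4 drawn S at this ring carbon it stays open whether the configuration at the chain carbon or at the other ring carbon alters the drop. The compounds shown also do not say whether the drop would persist with a methyl ester in place of the carboxylic acid.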